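The source may hold more compounds than are shown below. What is called first, only, known or untested is meant among the compounds shown, and "the series" means these compounds.

Measured in an ADME assay for permeability, using PAMPA, with a stated time of 5 h; on this read-out higher numbers stand for higher permeability and lower numbers for lower permeability:
- compound 1 `COCCc1cn(-c2ccc(NC(=O)Nc3ccccc3C)cc2)nn1`: 0.69 10^-6 cm/s
- compound 2 `CCOP(=O)(OCC)OCCc1cn(-c2ccc(NC(=O)Nc3ccccc3C)cc2)nn1`: 0.72 10^-6 cm/s
- compound 3 `CC(C)CC(=O)OCCc1cn(-c2ccc(NC(=O)Nc3ccccc3C(F)(F)F)cc2)nn1`: 4.24 10^-6 cm/s

Compound 2, at 0.72 10^-6 cm/s, stands level with compound 1 and well under compound 3, the highest of the three at 4.24 10^-6 cm/s. The next compound, compound 4 `CCCCc1cn(-c2ccc(NC(=O)Nc3ccccc3C)cc2)nn1`, is reached from compound 2 by a single change: a group of 2 heavy atoms (2 carbon; no ring) in place of a group of 9 heavy atoms (4 carbon, 4 oxygen, 1 phosphorus; no ring), on a saturated chain carbon, two bonds along the chain from an aromatic carbon.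

Within the data shown here, only one measured step bears on this part of the molecule. That step is a 1.0-fold higher number from compound 1 to compound 2 (0.02 log units; within the scatter), and it stays within the scatter despite the size of the group exchanged. Among the measured compounds shown here, compound 3 is joined to the others by no single-place step, so it gives no direct measure of this change. On this evidence, no step beyond the scatter is expected in this assay, with a slight lean towards a higher number. The estimated step is a 1.7-fold higher number from compound 2 to compound 4 (0.22 log units; within the scatter). The expected range is kept wider on the upper side because compound 3 gives 4.24 10^-6 cm/s. For compound 4 the estimate is 1.2 10^-6 cm/s, with an expected range from 0.45 10^-6 cm/s to 3.5 10^-6 cm/s.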

Compound 4, apparent permeability: 2.86 10^-6 cm/s
The estimate for compound 4 lay 2.4-fold (0.38 log units) below the measured number; measured number inside the range.
By their numbers in this assay, from the lowest: compounds 1 and 2 (each within the scatter of the next); then compounds 4 and 3 (each within the scatter of the next).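

In this assay, the saturated chain carbon, two bonds along the chain from an aromatic carbon, turns out to be a place where a change can move the number: ethyl in place of methoxy gives a 4.1-fold higher number from compound 1 to compound 4 (0.62 log units; beyond the scatter), and ethyl in place of the group of 9 heavy atoms gives a 4.0-fold higher number from compound 2 to compound 4 (0.60 log units; beyond the scatter). The two oxygen-bearing groups had stayed level, with a 1.0-fold higher number from compound 1 to compound 2 (0.02 log units; within the scatter), so among compounds 1, 2 and 4 the size of the group does not order the numbers, and only the ethyl compound stands apart. Nothing given here accounts for this difference. Going by these compounds, whether it follows from the loss of oxygen or from the all-carbon chain itself stays open, and a longer chain, an amine or a carboxylic acid at this place would test that. Compound 3 differs from these compounds in more than one place and cannot settle it.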